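The source may hold more compounds than are shown below. What is called first, only, known or untested is meant among the compounds shown, and "the series" means these compounds.

Measured compounds in the series:

- compound 1 `COc1ccc(CSc2nc(Cc3ccccc3Br)c(C)c(=O)[nH]2)cc1` — in an ADME assay on MT4 cells (Homo sapiens) for cytotoxicity, read by MTT assay (a higher number here means that more compound is tolerated, a lower number that less compound is tolerated), compound 1 gives 179000 nM
- compound 2 `COc1ccc(CSc2nc(Cc3cccc(Br)c3)c(C)c(=O)[nH]2)cc1` — compound 2 gives > 290000 nM, which is a limit of the assay and not a number
- compound 3 `COc1ccc(CSc2nc(Cc3ccc(Br)cc3)c(C)c(=O)[nH]2)cc1` — compound 3 gives > 290000 nM, again a limit and not a number

Compound 3 therefore stands at the top of what the assay can report; the same is true of compound 2 (the limit of > 290000 nM in this assay, at which 2 of the 3 values shown sit). Going by the values given here, the one readable number belongs to compound 1, and the move away from it is an at least 1.6-fold higher number from compound 1 to compound 3 (0.20 log units; that floor lies within the scatter), a floor that does not clear the scatter. Between the two limits the step that the two limits leave unreadable from compound 2 to compound 3 cannot be read at all.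

Compound 4 `COc1ccc(CSc2nc(Cc3ccc(-c4ccccc4)cc3)c(C)c(=O)[nH]2)cc1` differs from compound 3 by phenyl in place of bromo on an aromatic carbon, on an aromatic carbon of a six-membered aromatic ring of carbon only. Among the compounds with values here, no measured step exchanges bromo for phenyl; all three move the bromo around the ring and stay within the scatter or at the limit. On that basis no step beyond the scatter is expected for compound 4 in this assay, but a value near or just under the limit is plausible. Compound 4 is estimated at 230000 nM, within 90000 nM to 400000 nM, meaning an expected step of an at least 1.2-fold lower number from compound 3 to compound 4 (0.10 log units; that floor lies within the scatter).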

Compound 4, half-maximal cytotoxic concentration: 100000 nM
For compound 4 the middle estimate is 2.3-fold (0.36 log units) above the measured one, within the range that was stated.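

In this assay, going by these compounds alone, phenyl in place of bromo, para to a large group, gives an at least 2.9-fold lower number from compound 3 to compound 4 (0.46 log units; beyond the scatter), the only readable step that is printed as beyond the scatter. Within the data shown here, the earlier steps only moved the bromo around the ring, so this is the first indication that the group held at this position, and not just where the bromo sits, can change how much compound is tolerated. The size of the step remains a floor because compound 3 sits at a limit and not at a number: the limit of > 290000 nM in this assay, at which 2 of the 4 values shown sit.

Open, as far as these compounds go, is whether a saturated cyclohexyl ring, a morpholine or a carboxylic acid at this position would give a similar step. Also open, from the compounds shown here alone, is whether phenyl moved around the ring, as the bromo was, would keep this step.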